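Bromo to hydroxy on the aryl group of compound 1

The source may hold more compounds than are shown below. What is called first, only, known or untested is meant among the compounds shown, and "the series" means these compounds.

Measured in a functional assay on Malme-3M cells (Homo sapiens) for cytotoxicity, read by MTT assay, with a stated time of 6 days; a lower number here means that less compound is needed, a higher number that more compound is needed for the effect:
compound 1 `COC(=O)c1c(-c2ccc(Br)cc2)oc2ccccc2c1=O`: > 25 ug/mL
compound 2 `COC(=O)c1c(-c2ccc([N+](=O)[O-])cc2)oc2cc(OC)ccc2c1=O`: 1.12 ug/mL
compound 3 `COC(=O)c1c(-c2ccc(OCc3ccccc3)cc2)oc2ccc(OC)cc2c1=O`: > 25 ug/mL

Compound 1 gives > 25 ug/mL, which is a limit and not a number. Compound 3 gives > 25 ug/mL, also a limit. Among the compounds with values here, the series so far shows (the limit of > 25 ug/mL in this assay, at which 2 of the 3 values shown sit), and compound 2 goes against this at 1.12 ug/mL.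

Compound 4 `COC(=O)c1c(-c2ccc(O)cc2)oc2ccccc2c1=O` has hydroxy in place of bromo on an aromatic carbon, para to a large group: hydroxy in place of bromo on an aromatic carbon. Within the data shown here, no measured pair differs in one place only, so the expectation rests on little. In this assay, the expected step of an at least 1.2-fold lower number from compound 1 to compound 4 (0.09 log units; that floor lies within the scatter) is small and toward a lower number, and a further limit remains possible. For compound 4 the estimate is 20 ug/mL, with an expected range of 7 ug/mL to 50 ug/mL.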

Compound 4, concentration for half-maximal effect: > 25 ug/mL
Compound 4 was reported as a limit; the forecaster's own chance of this, stated with the estimate: 55%; middle value at least 1.2-fold (0.09 log units) away from the limit.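

No step can be read from compound 1 to compound 4, as both stand only as limits in this assay. From the compounds shown here alone, whether hydroxy in place of bromo changes the concentration needed at all remains open.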